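A few compounds are considered here, and "the series" means these few. Any claim that something is new, unique, unknown or untested is made for them only; others in the source may bear on it.

Compound 1 `C=CCNc1[nH]nc2nnn(-c3ccc(OCC)cc3)c(=O)c12` opens the account. In a functional assay on CCRF-CEM cells (Homo sapiens) for cytotoxicity, read by resazurin assay, with a stated time of 48 h (a higher number here means a weaker inhibitor, a lower number a stronger inhibitor), compound 1 gives 4730 nM, the lowest of the two numbers recorded so far. Among the compounds with values here, the only other measured compound, compound 2 `CCOc1ccc(NC(=O)/C(C#N)=C(\NC)SC)cc1`, is built on a different skeleton and cannot be tied to compound 1 by a single structural change; in this assay compound 2 gives 9940 nM, a higher number that lies beyond the usual scatter, so compound 1 stands as the stronger of the pair.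

The compound still to be tested is compound 3 `CCOc1ccc(-n2nnc3n[nH]c(Nc4ccccc4)c3c2=O)cc1`. It differs from compound 1 in one place: phenyl in place of allyl on a nitrogen on an aromatic ring. Within the data shown here, no pair of measured compounds separated by a single change is available, so the size of this step cannot be read off earlier data. Judged only from the shared core and the change itself, the step in this assay is expected to be a 1.6-fold lower number from compound 1 to compound 3 (0.20 log units; within the scatter), a small shift toward a lower number that may well stay within the scatter. Compound 3 is therefore expected to give 3000 nM in this assay, within a range from 1000 nM to 12000 nM.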

Compound 3, half-maximal inhibitory concentration: 5920 nM
Compound 3: the middle estimate sits 2.0-fold (0.30 log units) below what was measured, within the range that was stated.
By their numbers in this assay, from the lowest: compounds 1, 3 and 2 (each within the scatter of the next, the first and the last beyond it).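

In this assay, within the data shown here, the replacement of allyl by phenyl on this nitrogen gives a 1.3-fold higher number from compound 1 to compound 3 (0.10 log units; within the scatter) and so supplies the first single-change comparison, which the earlier compounds could not offer. It shows that this position accepts a six-membered aromatic ring of carbon in place of allyl, and that the double bond outside aromatic rings carried by allyl is not required to keep the number at this level, with no shift that can be told from the scatter. Nothing measured here bears on what lies behind this result.

The compounds shown leave open how a benzyl group, a longer alkyl chain or a phenyl carrying a carboxylic acid would read on this same nitrogen, since one step between two groups describes only those two. On these data alone, compound 2 stands on a different skeleton and adds nothing on this point, so it also remains open whether the change from allylamino to anilino would read the same way on any other core.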